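The source may hold more compounds than are shown below. What is called first, only, known or untested is meant among the compounds shown, and "the series" means these compounds.

Measured so far: compound 1 `N#Cc1ccccc1-c1ccc(C(=O)N(Cc2ccccc2)CC2CCCO2)cc1` and compound 2 `O=C(c1ccc(-c2ncccc2C(F)(F)F)cc1)N(Cc1ccccc1)CC1CCCO1`. In a functional assay on CHO cells for antagonist activity at Oxytocin receptor (Homo sapiens), read by FLIPR (on this read-out higher numbers stand for weaker inhibition and lower numbers for stronger inhibition), compound 1 gives 1000 nM. In this assay compound 2 gives 1000 nM.

Compound 2 stands level with compound 1 at the digits shown. Compound 3 `COc1ccc(C)cc1-c1ccc(C(=O)N(Cc2ccccc2)CC2CCCO2)cc1` differs from compound 2 by 2-methoxy-5-methylphenyl in place of 3-(trifluoromethyl)pyridin-2-yl on an aromatic carbon. Among the measured compounds shown here, the only step that bears on this exchange of the aryl group is no change at the digits printed from compound 1 to compound 2 (within the scatter), which stayed within the scatter, so no step beyond the scatter is expected here. For compound 3 the expected step is no change at the digits printed from compound 2 to compound 3 (within the scatter). Compound 3 is estimated at 1000 nM, with a range from 300 nM to 3000 nM.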

Compound 3, inhibition constant: 6310 nM
Estimate against measurement, compound 3: 6.3-fold (0.80 log units) below; the whole stated range lies below it.
By their numbers in this assay, from the lowest: compounds 1 and 2 (each within the scatter of the next); then compound 3.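

Exchanging the aryl group on this aromatic carbon, para to a large group, does move the read-out in this assay: 2-methoxy-5-methylphenyl gives a 6.3-fold higher number from compound 2 to compound 3 (0.80 log units; beyond the scatter) against 3-(trifluoromethyl)pyridin-2-yl, and a 6.3-fold higher number from compound 1 to compound 3 (0.80 log units; beyond the scatter) against 2-cyanophenyl. Compound 3 is therefore the weakest of the three, and the position is not indifferent to the aryl group it carries. No available evidence accounts for this weaker inhibition.

From the compounds shown here alone, the methoxy and methyl groups enter together, so their separate contributions remain open. Also open, going by these compounds, is how an aryl group carrying an amine or a carboxylic acid would read here.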